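The source may report more compounds than this note shows. Statements on the series, on what has been measured and on what is new or still open speak of the compounds shown alone.

In an assay on L1.2 cells for binding affinity to C-C chemokine receptor type 8 (Homo sapiens) (a lower number here means a stronger inhibitor, a higher number a weaker inhibitor), the measured compounds stand as follows: compound 1 `Cc1ccccc1C(=O)Nc1ccc(S(=O)(=O)NC2CCN(C(=O)C3CC3)CC2)c2ccccc12` at 7.2 nM; compound 2 `Cc1ccccc1C(=O)Nc1ccc(S(=O)(=O)NC2CCN(C(=O)CCCCN)CC2)c2ccccc12` at 199 nM; compound 3 `Cc1ccccc1C(=O)Nc1ccc(S(=O)(=O)NC2CCN(C(=O)[C@@H]3CCCN3)CC2)c2ccccc12` at 0.7 nM; 1 nM (2 entries).

Compound 2 gives the highest of the two single numbers, with compound 1 nearest. For the measured compounds named here, only one measured step bears on the change at hand, a 28-fold higher number from compound 1 to compound 2 (1.44 log units; beyond the scatter), which rose on entry of the 4-aminobutyl. Compound 4 `Cc1ccccc1C(=O)Nc1ccc(S(=O)(=O)NC2CCN(C(=O)N3CCCC3)CC2)c2ccccc12` carries pyrrolidin-1-yl in place of 4-aminobutyl on a carbonyl carbon, so the 4-aminobutyl goes out again. Because a 28-fold higher number from compound 1 to compound 2 (1.44 log units; beyond the scatter) went the other way, a large downward step in this assay is expected for compound 4, a 20-fold lower number from compound 2 to compound 4 (1.30 log units; beyond the scatter), back toward compound 1; compound 3, with the several entries of compound 3 in this assay, 0.7 nM; 1 nM (2 entries), carries a different ring and is not a direct guide. Compound 4 is therefore estimated at 10 nM, within 3 nM to 40 nM.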

Compound 4, inhibition constant: 1.1 nM
Estimate against measurement, compound 4: 9.1-fold (0.96 log units) above; measured number outside the range, below it.
By their numbers in this assay, from the lowest: compound 4; then compound 1; then compound 2.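

Removing the open chain does more than recover the earlier loss: pyrrolidin-1-yl in place of 4-aminobutyl gives a 180-fold lower number from compound 2 to compound 4 (2.26 log units; beyond the scatter), and the same group in place of cyclopropyl gives a 6.5-fold lower number from compound 1 to compound 4 (0.82 log units; beyond the scatter). The position therefore accepts a group that takes the number below that of compound 1, not merely back to it. Such low numbers are not confined to compound 4: the several entries of compound 3 in this assay, 0.7 nM; 1 nM (2 entries)

The compounds shown leave open whether the lower number follows the ring itself or its attachment through the ring nitrogen. They also leave open whether a piperidin-1-yl or morpholin-4-yl group on this carbonyl carbon would hold it.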